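The source may report more compounds than this note shows. Statements on the series, on what has been measured and on what is new or still open speak of the compounds shown alone.

Measured so far in an ADME assay on Vero cells (Chlorocebus sabaeus) for cytotoxicity, read by resazurin assay, with a stated time of 3 days; on this read-out higher numbers stand for weaker inhibition and lower numbers for stronger inhibition:
Compound 1 `CCCNC(=O)Nc1cc2nc(C3CCCCC3)[nH]c2cc1N(CC)CC` gives only a limit, > 100 ug/mL.
Compound 2 `CCN(CC)c1cc2[nH]c(C3CCCCC3)nc2cc1NC(=O)c1ccc(OC(F)(F)F)cc1` gives only a limit, > 100 ug/mL.
Compound 3 `CCN(CC)c1cc2[nH]c(C3CCCCC3)nc2cc1NC(=O)c1ccc(OC(F)F)cc1` gives only a limit, > 100 ug/mL.

Compound 3 thus stands at the limit of > 100 ug/mL in this assay, at which 3 of the 3 values shown sit, and its true number is not known. The measured steps a step that the two limits leave unreadable from compound 1 to compound 2, a step that the two limits leave unreadable from compound 1 to compound 3 and a step that the two limits leave unreadable from compound 2 to compound 3 carry no readable size, so nothing here shows a direction for a further change at the carbonyl carbon. Compound 4 `CCN(CC)c1cc2[nH]c(C3CCCCC3)nc2cc1NC(=O)c1cnccn1` differs from compound 3 by pyrazin-2-yl in place of 4-(difluoromethoxy)phenyl on a carbonyl carbon. With all three values sitting at the limit, the step is expected to be none beyond the scatter, estimated as a number no higher from compound 3 to compound 4 (the limit leaves the size open). Compound 4 is accordingly expected to give about 100 ug/mL in this assay, within 50 ug/mL to 200 ug/mL, most likely reported again only as a limit.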

Compound 4, half-maximal inhibitory concentration: > 100 ug/mL
Compound 4: a limit, no number; the forecaster's own chance of this, stated with the estimate: 85%; the middle value lies on the limit itself.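

In this assay compound 4 gives only a limit, > 100 ug/mL, so its steps from compound 1, compound 2 and compound 3 cannot be read. The compounds shown leave open whether any change on the carbonyl carbon alters the true number in this assay.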